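A few compounds are considered here, and "the series" means these few. Any claim that something is new, unique, unknown or untested is made for them only; others in the source may bear on it.

Series notes, cytotoxicity set.

The shared core carries a para-substituted or meta-substituted benzoyl group at the far end. Compound 1 `COc1ccc2[nH]cc(CCCN3CCN(C(=O)CN4CCN(C(=O)c5ccc(Br)cc5)CC4)CC3)c2c1` is the 4-bromophenyl member; in an ADME assay on SH-SY5Y cells (Homo sapiens) for cytotoxicity, read by MTT assay, with a stated time of 72 h (on this read-out higher numbers stand for weaker inhibition and lower numbers for stronger inhibition), compound 1 gives 150000 nM. Compound 2 `COc1ccc2[nH]cc(CCCN3CCN(C(=O)CN4CCN(C(=O)c5ccc(F)cc5)CC4)CC3)c2c1` is the 4-fluorophenyl member; in this assay compound 2 reaches only > 200000 nM, which is a limit of the assay and not a number, as recorded in the limit of > 200000 nM in this assay, at which 1 of the 3 values shown sits. Compound 3 `COc1ccc2[nH]cc(CCCN3CCN(C(=O)CN4CCN(C(=O)c5cccc(Br)c5)CC4)CC3)c2c1` is the 3-bromophenyl member; in this assay compound 3 gives 105000 nM.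

Measured steps: an at least 1.3-fold higher number from compound 1 to compound 2 (0.12 log units; that floor lies within the scatter), with the change (fluoro in place of bromo on an aromatic carbon). a 1.4-fold lower number from compound 1 to compound 3 (0.15 log units; within the scatter), with the change (3-bromophenyl in place of 4-bromophenyl on a carbonyl carbon). an at least 1.9-fold lower number from compound 2 to compound 3 (0.27 log units; that floor lies within the scatter). All three steps sit within the scatter, so no order among compounds 1, 2 and 3 is established here.

Compound 4 `COc1ccc2[nH]cc(CCCN3CCN(C(=O)CN4CCN(C(=O)c5cccc(F)c5)CC4)CC3)c2c1` is not yet measured in this assay. It differs from compound 3 by fluoro in place of bromo on an aromatic carbon. For the measured compounds named here, this is the same kind of change as the one from compound 1 to compound 2, but the place differs: there the fluoro enters para to a large group, here meta to a large group.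

For compound 4 the step is expected to be a 1.6-fold higher number from compound 3 to compound 4 (0.21 log units; within the scatter), which rests on the earlier step of an at least 1.3-fold higher number from compound 1 to compound 2 (0.12 log units; that floor lies within the scatter) being a floor that already lies within the scatter, and on compound 3 starting at 105000 nM. Compound 4 is therefore expected to give about 170000 nM in this assay, with a range from 100000 nM to 300000 nM, and a real chance that only a limit is reported.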

Compound 4, half-maximal inhibitory concentration: > 200000 nM
Compound 4 gave a limit, no number; the forecaster's own chance of this, stated with the estimate: 40%; at least 1.1-fold (0.07 log units) between middle value and limit.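

In this assay, for the compounds shown here, fluoro in place of bromo gives an at least 1.9-fold higher number from compound 3 to compound 4 (0.27 log units; that floor lies within the scatter), and 3-fluorophenyl in place of 4-bromophenyl gives an at least 1.3-fold higher number from compound 1 to compound 4 (0.12 log units; that floor lies within the scatter), while the steps that join two limits, such as the one between compound 2 and compound 4, cannot be read. Compound 2 and compound 4 both stop at a limit of the assay and not at a number: the limit of > 200000 nM in this assay, at which 2 of the 4 values shown sit. The change from bromo to fluoro is thus seen on two cores, but no size is shown to carry from one core to the other, and neither step is shown to lie beyond the scatter: the same change on two cores in this assay, an at least 1.3-fold higher number (0.12 log units; that floor lies within the scatter) from compound 1 to compound 2 and an at least 1.9-fold higher number (0.27 log units; that floor lies within the scatter) from compound 3 to compound 4; the limit leaves it open whether they differ.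

The compounds shown leave open how a chloro or a methyl group on the same aromatic carbon would read in this assay, on either core. They also leave open what an amine or a carboxylic acid on the benzoyl ring, or a longer chain within the shared core, would give in this assay, and whether any such change would produce a number clear of the limit and a step beyond the scatter.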